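Opening the Indane Ring: From Compound 3 to Compound 4

A few compounds are considered here, and "the series" means these few. Any claim that something is new, unique, unknown or untested is made for them only; others in the source may bear on it.

Compound 1 `c1ccc(CNCC2CCN(CCCc3c[nH]c4ccc(-n5cnnc5)cc34)CC2)cc1`, compound 2 `c1ccc(C2CCCCN2C2CCN(CCCc3c[nH]c4ccc(-n5cnnc5)cc34)CC2)cc1` and compound 3 `c1ccc2c(c1)CCC2NC1CCN(CCCc2c[nH]c3ccc(-n4cnnc4)cc23)CC1` share one core and differ only in the group carried on the saturated ring. In an assay on CHO cells for agonist activity at 5-hydroxytryptamine receptor 1D (Homo sapiens), read by GTPgammaS binding (on this read-out higher numbers stand for an effect only at larger amounts of compound and lower numbers for an effect already at smaller amounts), compound 1 gives 5.6 nM. In this assay compound 2 gives 4.7 nM. In this assay compound 3 gives 25 nM, the highest of the three numbers, with both other compounds beyond the scatter below it. Among the measured compounds shown here, the one measured step that reaches compound 3 is a 4.5-fold higher number from compound 1 to compound 3 (0.65 log units; beyond the scatter), a modest worsening. Compound 4 `OCCC(NC1CCN(CCCc2c[nH]c3ccc(-n4cnnc4)cc23)CC1)c1ccccc1` has not yet been measured; it differs from compound 3 by 3-hydroxy-1-phenylpropyl in place of 2,3-dihydro-1H-inden-1-yl on an amine nitrogen. For the measured compounds named here, the step from compound 1 to compound 3 bears on this change only loosely, since it shows that the arrangement of the aryl-bearing group on the amine nitrogen can shift the number by a modest amount; no measured pair covers the entering hydroxyl. Compound 4 is therefore expected to land near the other two compounds, at 12 nM with a range from 4 nM to 50 nM, which would be an estimated 2.1-fold lower number from compound 3 to compound 4 (0.32 log units; beyond the scatter).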

Compound 4, half-maximal effective concentration: 5.1 nM
Beside the measured number, compound 4's estimate is 2.4-fold (0.37 log units) above it; measured number inside the range.
By their numbers in this assay, from the lowest: compounds 2, 4 and 1 (each within the scatter of the next); then compound 3.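

In this assay, putting 3-hydroxy-1-phenylpropyl in place of 2,3-dihydro-1H-inden-1-yl on an amine nitrogen gives a 4.9-fold lower number from compound 3 to compound 4 (0.69 log units; beyond the scatter), so this position accepts a group that has lost the five-membered non-aromatic ring and gained a hydroxyl. Putting (3-hydroxy-1-phenylpropyl)amino in place of (benzylamino)methyl on a saturated ring carbon gives a 1.1-fold lower number from compound 1 to compound 4 (0.04 log units; within the scatter), so these two groups cannot be told apart in this measurement. The higher number of compound 3 is therefore not shared by this ring-free group.

Nothing available explains why the number changes with this swap. On these data alone, the ring and the hydroxyl change together, so it stays open whether a plain 1-phenylpropyl group, or one with a methoxy or an amine in place of the hydroxyl, would give a similar number.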